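Furan-amine quinoline series: cytotoxicity after changing the aryl group

A few compounds are considered here, and "the series" means these few. Any claim that something is new, unique, unknown or untested is made for them only; others in the source may bear on it.

Compound 1 `COc1ccccc1Oc1ccc2c(NCCCNCc3ccco3)ccnc2c1` gives 6500 nM in an ADME assay on HepG2 cells (Homo sapiens) for cytotoxicity, read by luminescence, CellTiter-Glo and ATP content, with a stated time of 72 h; a lower number here means that less compound is needed, a higher number that more compound is needed for the effect. Compound 2 `COc1ccc(-c2ccc3c(NCCCNCc4ccco4)ccnc3c2)cc1` gives 6000 nM in this assay, and compound 3 `CC(C)(C)c1ccc(-c2ccc3c(NCCCNCc4ccco4)ccnc3c2)cc1` gives 3150 nM in this assay. Compound 3 stands at the lowest of the three numbers; its gap to compound 2 is within the scatter and its gap to compound 1 is just beyond it, so on these numbers compound 3 is set apart only from compound 1.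

The steps measured so far all sit on the same aromatic carbon of the shared core. a 1.1-fold lower number from compound 1 to compound 2 (0.03 log units; within the scatter). a 2.1-fold lower number from compound 1 to compound 3 (0.31 log units; beyond the scatter). a 1.9-fold lower number from compound 2 to compound 3 (0.28 log units; within the scatter).

Compound 4 `c1ccc(Cc2ccc3c(NCCCNCc4ccco4)ccnc3c2)cc1` differs from compound 3 in one place: benzyl in place of 4-(tert-butyl)phenyl on an aromatic carbon. Among the compounds with values here, the steps that bear on this are those that swapped the group on that carbon, and the only one beyond the scatter was from compound 1 to compound 3, which was itself modest. A change from 4-(tert-butyl)phenyl to benzyl is expected to move the number back toward those of compound 1 and compound 2 rather than further down, by a step no larger than a 1.9-fold lower number from compound 2 to compound 3 (0.28 log units; within the scatter) in reverse. Compound 4 is therefore expected to give 5000 nM in this assay, with a range from 2500 nM to 10000 nM. The expected step of a 1.6-fold higher number from compound 3 to compound 4 (0.20 log units; within the scatter) is estimated to lie within the scatter.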

Compound 4, half-maximal effective concentration: 16000 nM
Compound 4: the middle estimate sits 3.2-fold (0.51 log units) below what was measured; measured number above the stated range.
By their numbers in this assay, from the lowest: compounds 3, 2 and 1 (each within the scatter of the next, the first and the last beyond it); then compound 4.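

Notes on this position: in this assay, the aromatic carbon carrying the aryl group can move the number upward, and compound 4 is the only compound so far set apart from all the others (a 5.1-fold higher number from compound 3 to compound 4 (0.71 log units; beyond the scatter); a 2.7-fold higher number from compound 2 to compound 4 (0.43 log units; beyond the scatter); a 2.5-fold higher number from compound 1 to compound 4 (0.39 log units; beyond the scatter)). The earlier groups had shown only a modest spread, with compound 1 and compound 3 the only pair beyond the scatter, so this change marks the position as more sensitive than those compounds suggested. Benzyl and 4-(tert-butyl)phenyl each hold one six-membered aromatic ring of carbon only, so keeping such a ring at this carbon does not by itself hold the number near the earlier values, and no measurement shown here explains the rise.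

Still open, as far as these compounds go, is whether the higher number follows the carbon link of benzyl or the absence of a substituent on its ring, which a plain phenyl or a 4-(tert-butyl)benzyl group at this carbon would help separate. Also open, from the compounds shown here alone, is how a basic amine or a carboxylic acid on the same ring would place in this assay relative to these four compounds.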